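Bromo in place of trifluoromethyl: one change in the series

The source may hold more compounds than are shown below. What is called first, only, known or untested is meant among the compounds shown, and "the series" means these compounds.

Measured so far:
compound 1, `CCc1ccc(Nc2cc(NC(=O)Nc3cc(OC)cc(OC)c3)ncn2)cc1`, 23.5%
compound 2, `COc1cc(NC(=O)Nc2cc(Nc3cc(C(F)(F)F)ccc3OC)ncn2)cc(OC)c1`, 63%

Both compounds were tested in a functional assay on NCI-H520 cells (Homo sapiens) for inhibition, read by MTT assay, with a stated time of 48 h, tested at 10 uM; on this read-out higher numbers stand for more inhibition at the one concentration tested (going by the name of the read-out) and lower numbers for less inhibition. Compound 1 gives 23.5%, and compound 2 gives 63%. Compound 2 thus stands highest of the two numbers; its nearest neighbour is compound 1, which lies lower by an amount beyond the scatter. Among the compounds with values here, the two measured compounds differ in more than one place, so no single-point step between them can be drawn, and only the two values themselves can be set side by side.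

The next compound, compound 3, `COc1cc(NC(=O)Nc2cc(Nc3cc(Br)ccc3OC)ncn2)cc(OC)c1`, differs from compound 2 in one place: bromo in place of trifluoromethyl on an aromatic carbon. Within the data shown here, nothing among the measured compounds shows what bromo does at this position, so the expectation rests on the value of compound 2 alone. In this assay the step is expected to be small, a modest fall or none beyond the scatter, and is estimated as a number 11 percentage points lower from compound 2 to compound 3 (beyond the scatter). Compound 3 is accordingly estimated at 52% in this assay, with a range of 28% to 76%.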

Compound 3, a percentage reported as inhibition, at one concentration (the size of the read-out at that concentration, not a potency): 43.5%
Compound 3: middle estimate off by 8.5 percentage points, on the high side; the measured number falls inside the stated range.
By their numbers in this assay, from the lowest: compound 1; then compound 3; then compound 2.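

In this assay the aromatic carbon para to a methoxy group now has its first readable step: bromo in place of trifluoromethyl gives a number 19.5 percentage points lower from compound 2 to compound 3 (beyond the scatter), so the number at this position depends on which of these two groups it carries. The aryl group on the nitrogen can now also be read as a single change, since 5-bromo-2-methoxyphenyl in place of 4-ethylphenyl gives a number 20 percentage points higher from compound 1 to compound 3 (beyond the scatter), and compound 3 takes the middle place between compound 1 and compound 2, which until now could only be set side by side as two values differing in more than one place. No measurement at hand bears on why either step has the size it has.

Still open, on these data alone, is how other groups would read on the same aromatic carbon, for instance an amine, a nitrile or a carboxylic acid, and whether the methoxy group on that ring contributes anything, which a compound with a hydrogen in its place would show. Also open, as far as these compounds go, is whether the order of compound 3 and compound 2 holds in other cell lines or across a range of concentrations.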